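The source may report more compounds than this note shows. Statements on the series, on what has been measured and on what is new or still open speak of the compounds shown alone.

Compounds measured in a functional assay on KYSE-510 cells (Homo sapiens) for antiproliferative activity, read by crystal violet staining, with a stated time of 96 h (on this read-out lower numbers stand for stronger inhibition of growth and higher numbers for weaker inhibition of growth), so far:

Compound 1 `Cc1ccc(S(=O)(=O)NC2=NCCN2C(=S)SN2CCn3c2nsc3=S)cc1` — in this assay compound 1 gives >= 20000 nM, a limit of the assay rather than a number.
Compound 2 `O=S(=O)(NC1=NCCN1C(=S)SN1CCn2c1nsc2=S)c1ccc(Br)cc1` — in this assay compound 2 gives >= 20000 nM, again a limit.
Compound 3 `O=S(=O)(NC1=NCCN1C(=S)SN1CCn2c1nsc2=S)c1cc(Cl)cc(Cl)c1` — in this assay compound 3 gives >= 20000 nM, also a limit.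

All three values sit at the same limit, so the steps among them are not readable: a step that the two limits leave unreadable from compound 1 to compound 2, a step that the two limits leave unreadable from compound 1 to compound 3 and a step that the two limits leave unreadable from compound 2 to compound 3 all stay unresolved, with no size to be taken from them (the limit of >= 20000 nM in this assay, at which 3 of the 3 values shown sit). Compound 3 therefore stands nowhere definite relative to compound 1 or compound 2; it is merely one of three compounds at the limit.

Compound 4 `O=S(=O)(NC1=NCCN1C(=S)SN1CCn2c1nsc2=S)c1ccc2ccccc2c1` differs from compound 3 as follows: naphthalen-2-yl in place of 3,5-dichlorophenyl on a sulfonyl sulfur. Within the data shown here, no measured step bears on this change, as every step in the set is unreadable. Among the measured compounds shown here, the only information is that three different aryl groups on the sulfonyl sulfur, including the 3,5-dichlorophenyl of compound 3, all leave the shared core at the limit of this assay. The expectation for the step from compound 3 to compound 4 is accordingly one of no readable change, a number no higher from compound 3 to compound 4 (the limit leaves the size open), and compound 4 is estimated at 20000 nM with a range of 6000 nM to 40000 nM, most likely to be reported again as a limit.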

Compound 4, concentration for 50% growth inhibition: >= 20000 nM
Compound 4: only a limit was reported (the forecaster's own chance of this, stated with the estimate: 75%); the middle value sits exactly at the limit.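

Compound 4 sits at the same limit as compound 1, compound 2 and compound 3, so no step among these compounds can be read: the limit of >= 20000 nM in this assay, at which 4 of the 4 values shown sit.

The compounds shown leave open whether the aryl group on the sulfonyl sulfur affects growth inhibition at all, as none of them gives a number rather than a limit.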